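The source may hold more compounds than are shown below. What is called first, only, known or untested is meant among the compounds shown, and "the series" means these compounds.

Series notes, cytotoxicity arm. Compound 3 `O=C1O[C@@H](CSc2cccs2)CN1c1ccc(-n2cc(-c3ccccn3)cn2)c(F)c1` carries a (thiophen-2-yl)sulfanyl group on a saturated chain carbon bound to a saturated ring carbon. In an ADME assay on L02 cells (Homo sapiens) for cytotoxicity, read by MTT assay, with a stated time of 48 h (on this read-out lower numbers stand for stronger inhibition and higher numbers for weaker inhibition), compound 3 gives > 400 ug/mL, which is a limit of the assay and not a number. Compound 1 `COC(=O)CC1CCN(C[C@H]2CN(c3ccc(-n4cc(-c5ccccn5)cn4)c(F)c3)C(=O)O2)CC1` also reaches only a limit, giving > 400 ug/mL in this assay. Compound 2 `CC(=O)OC[C@H]1CN(c2ccc(-n3cc(-c4ccccn4)cn3)c(F)c2)C(=O)O1` likewise gives > 400 ug/mL in this assay, again a limit. All three sit at the same ceiling (the limit of > 400 ug/mL in this assay, at which 3 of the 3 values shown sit), so none of a step that the two limits leave unreadable from compound 1 to compound 2, a step that the two limits leave unreadable from compound 1 to compound 3 or a step that the two limits leave unreadable from compound 2 to compound 3 carries a size, and compound 3 stands nowhere distinguishable from the other two on these numbers. Compound 4 `CCC(=O)NC[C@H]1CN(c2ccc(-n3cc(-c4ccccn4)cn3)c(F)c2)C(=O)O1` differs from compound 3 by propanoylamino in place of (thiophen-2-yl)sulfanyl on a saturated chain carbon bound to a saturated ring carbon. Among the measured compounds shown here, no measured step in this assay gives a direction for this change; the three earlier exchanges at the same position all left the read-out at the ceiling (the limit of > 400 ug/mL in this assay, at which 3 of the 3 values shown sit). The step of a number no higher from compound 3 to compound 4 (the limit leaves the size open) is therefore expected to be unreadable as well. Compound 4 is expected to give 400 ug/mL in this assay, within 200 ug/mL to 800 ug/mL, most likely again reported as a limit rather than a number.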

Compound 4, half-maximal inhibitory concentration: 204 ug/mL
The estimate for compound 4 lay 2.0-fold (0.29 log units) above the measured number; measured number inside the range.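

With propanoylamino on a saturated chain carbon bound to a saturated ring carbon, this assay returns a number for the first time, while the other compounds stay at a ceiling: the limit of > 400 ug/mL in this assay, at which 3 of the 4 values shown sit.

The exchange reads as an at least 1.9-fold lower number from compound 3 to compound 4 (0.29 log units; that floor lies within the scatter), as an at least 1.9-fold lower number from compound 2 to compound 4 (0.29 log units; that floor lies within the scatter) and as an at least 1.9-fold lower number from compound 1 to compound 4 (0.29 log units; that floor lies within the scatter). Each is only a floor, so the direction is readable but the true size is not, and the steps among compound 1, compound 2 and compound 3 cannot be read at all.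

Still open, going by these compounds, is how far the three ceiling compounds lie from compound 4, and whether the number follows propanoylamino as a whole or only its amide part. An acetylamino group, a longer acylamino chain or a free primary amine in the same place would separate these readings.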